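A few compounds are considered here, and "the series" means these few. Any claim that something is new, unique, unknown or untested is made for them only; others in the source may bear on it.

Measured so far in an ADME assay on the whole organism (Rattus norvegicus), at a dose of 2 mg/kg by the oral route; on this read-out higher numbers stand for higher exposure at the dose given and lower numbers for lower exposure:
- compound 1 `COc1cc(OCc2csc(-c3ccc(C(F)(F)F)cc3)n2)c2cc(-c3cn4nc(OC)sc4n3)oc2c1`: 726 ng.h/mL
- compound 2 `COc1cc(OCc2cccc(-c3cnc(OC)nc3)c2)c2cc(-c3cn4nc(OC)sc4n3)oc2c1`: 1030 ng.h/mL
- compound 3 `COc1cc(OCc2cccc(-c3cnc(OC)cn3)c2)c2cc(-c3cn4nc(OC)sc4n3)oc2c1`: 722 ng.h/mL

The three values lie within the scatter of one another, so compound 1 at 726 ng.h/mL cannot be separated from compound 2 or compound 3 in this assay. The next compound to be read is compound 4 `CNC(=O)c1ccc(-c2nc(COc3cc(OC)cc4oc(-c5cn6nc(OC)sc6n5)cc34)cs2)cc1`. Its difference from compound 1 is methylcarbamoyl in place of trifluoromethyl on an aromatic carbon, para to a large group.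

Going by the values given here, the only measured step between two compounds that differ in one place is a 1.4-fold lower number from compound 2 to compound 3 (0.15 log units; within the scatter). That step puts 5-methoxypyrazin-2-yl in place of 2-methoxypyrimidin-5-yl, stays within the scatter and involves neither group at issue here. It shows that one single exchange left the number unmoved, but it does not size the present change. Among the compounds with values here, no measured compound other than compound 1 carries the 4-(trifluoromethyl)phenyl group, so the data hold no direct precedent for this exchange. The direction is therefore a tentative judgement, and the range has to stay wide.

The expected change is modest and downward, a 1.6-fold lower number from compound 1 to compound 4 (0.21 log units; within the scatter).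

For compound 4 the estimated value is 450 ng.h/mL, with an expected range from 130 ng.h/mL to 1500 ng.h/mL.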

Compound 4, area under the concentration-time curve: 21.9 ng.h/mL
Beside the measured number, compound 4's estimate is 21-fold (1.31 log units) above it; measured number below the stated range.
By their numbers in this assay, from the lowest: compound 4; then compounds 3, 1 and 2 (each within the scatter of the next).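

In this assay, going by these compounds alone, the exchange of trifluoromethyl for methylcarbamoyl on the aromatic carbon, para to a large group, gives a 33-fold lower number from compound 1 to compound 4 (1.52 log units; beyond the scatter) and is the first step beyond the scatter, whereas the earlier exchange, a 1.4-fold lower number from compound 2 to compound 3 (0.15 log units; within the scatter), stayed within it. This position is therefore not indifferent to the group it carries in this assay, even though the two groups match in heavy-atom count and neither carries a ring or a net charge; what separates them in the computed comparison includes the hydrogen-bond donor and hydrogen-bond acceptor that enter with methylcarbamoyl. No measurement at hand bears on why the number falls, so the step stands as an observation only.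

The compounds shown leave open whether dimethylcarbamoyl, an unsubstituted carbamoyl group, a nitrile or a carboxylic acid at the same place would read with compound 1 or with compound 4, which would show whether the amide hydrogen, the carbonyl or the methyl group tracks with the fall. They also leave open whether the same exchange would give a step of similar size on a different aryl group attached to the shared core.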